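A few compounds are considered here, and "the series" means these few. Any claim that something is new, unique, unknown or untested is made for them only; others in the source may bear on it.

Compound 1 `COc1cc(/C=C/C(=O)C2=C(/C=C/c3ccc(O)c(OC)c3)NC(=O)NC2c2ccccc2Cl)ccc1O`: 50000 nM
Compound 2 `COc1cc(/C=C/C(=O)C2=C(/C=C/c3ccc(O)c(OC)c3)NC(=S)NC2c2ccccc2)ccc1O`: 100000 nM

In a functional assay on HCT-116 cells (Homo sapiens) for cytotoxicity, read by MTT assay, with a stated time of 48 h (a higher number here means a weaker inhibitor, a lower number a stronger inhibitor), compound 2 gives 100000 nM. Going by the values given here, that value lies within the usual scatter of the one for compound 1, so the numbers do not separate these two compounds. They also differ in more than one place, which means that no clean single-change comparison exists yet.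

The next compound to consider is compound 3 `COc1cc(/C=C/C(=O)C2=C(/C=C/c3ccc(O)c(OC)c3)NC(=S)NC2c2c(Cl)cccc2Cl)ccc1O`, which keeps the rest of compound 2 and alters one group: 2,6-dichlorophenyl in place of phenyl on a saturated ring carbon.

Among the compounds with values here, the only hint comes from compound 1, which also carries chlorine on its aromatic group and gives 50000 nM. It is a weak hint, since that compound differs elsewhere as well. The expected step, a 1.7-fold lower number from compound 2 to compound 3 (0.22 log units; within the scatter), is small and not clearly beyond the scatter, with a slight lean towards a lower number. For compound 3, the estimated value is 60000 nM, with an expected range from 20000 nM to 150000 nM.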

Compound 3, half-maximal inhibitory concentration: 50000 nM
The estimate for compound 3 lay 1.2-fold (0.08 log units) above the measured number, and the stated range covers the measured number.
By their numbers in this assay, from the lowest: compounds 1, 3 and 2 (each within the scatter of the next).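

Going by these compounds alone, compound 2 and compound 3 offer the first comparison in which only one group differs. In this assay, 2,6-dichlorophenyl in place of phenyl on a saturated ring carbon gives a 2.0-fold lower number from compound 2 to compound 3 (0.30 log units; within the scatter), so the numbers do not separate the two compounds, and this added pair of chlorine atoms shows no effect that can be told from ordinary assay variation. No separate measurement is available to help interpret this result.

The compounds shown leave open whether a different kind of group on this aromatic ring, such as an amine or a carboxylic acid, would give a number clearly apart from those of compound 2 and compound 3. They also leave the contribution of each single change in compound 1 unresolved, as compound 1 differs from compound 2 and from compound 3 in more than one place, so its value cannot be assigned to either the chlorine pattern or the ring carbonyl alone.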